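The compounds below may be only part of what the source reports. "The series", "measured", "known", "first", "only" and "open" are said of these compounds alone.

Measured compounds:
compound 1 `COc1ccc(-c2noc3cc(-c4ccccc4)n(C)c(=O)c23)cc1` gives 29 nM in a functional assay on CHO cells for antagonist activity at metabotropic glutamate receptor 7 (Rattus norvegicus), read by FLIPR and calcium flux; on this read-out lower numbers stand for stronger inhibition and higher numbers for weaker inhibition
compound 2 `Cn1c(-c2ccc(F)cc2)cc2onc(-c3ccccc3)c2c1=O` gives 72 nM in this assay

Of these two numbers compound 2 carries the highest in this assay. Among the measured compounds shown here, its only neighbour is compound 1, whose number lies lower by a margin beyond the usual scatter, so compound 2 is the weaker inhibitor of the pair. Compound 3 `CCCc1ccc(-c2cc3onc(-c4ccccc4)c3c(=O)n2C)cc1` has not yet been measured. It differs from compound 2 in one place: propyl in place of fluoro on an aromatic carbon. For the measured compounds named here, no pair of measured compounds shows exactly this exchange, so there is no measured step to lean on. Going by the values given here, what the two measured compounds show is only that a methoxy group in compound 1, where compound 2 carries the fluoro, goes with a lower number. On that slim basis a step of modest size toward a lower number is expected, a 1.4-fold lower number from compound 2 to compound 3 (0.16 log units; within the scatter), although a result within the scatter would not be surprising. Compound 3 is therefore estimated at 50 nM in this assay, with a range from 15 nM to 170 nM.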

Compound 3, half-maximal inhibitory concentration: 150 nM
Compound 3: middle estimate off by 3.0-fold (0.48 log units), on the low side, within the range that was stated.
By their numbers in this assay, from the lowest: compound 1; then compound 2; then compound 3.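

Among the compounds shown here, the exchange of fluoro for propyl on the aromatic carbon para to a large group gives the first measured step at this position: in this assay there is a 2.1-fold higher number from compound 2 to compound 3 (0.32 log units; beyond the scatter), a modest rise that lies beyond the usual scatter. The position is therefore not indifferent to this change, yet it does not lose the activity, since compound 3 still gives 150 nM. Neither group carries a hydrogen-bond donor, a hydrogen-bond acceptor or a net charge, and the counted difference is the three carbon atoms of the propyl against the single fluorine, though no measurement shown here bears on why the number rises.

A single pair cannot show whether the number climbs steadily with chain length, so a methyl, an ethyl or a longer chain such as butyl on the same aromatic carbon would be needed to draw that line. From the compounds shown here alone, how a plain hydrogen, a methoxy group, an amine or a carboxylic acid would fare at this carbon also remains open.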